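Swapping the aryl group at the saturated ring carbon

The compounds below may be only part of what the source reports. "The series", "measured", "known", "first", "only" and "open" are said of these compounds alone.

Within the data shown here, in a functional assay on Ehrlich cells (Mus musculus) for antiproliferative activity, read by trypan blue exclusion, with a stated time of 2 h (a higher number here means a weaker inhibitor, a lower number a stronger inhibitor), compound 2, `N#CC1=C(N)N(c2ccc(S(N)(=O)=O)cc2)C2=C(C(=O)CCC2)C1c1ccc(Cl)cc1Cl`, gives 25 ug/mL, the only actual number among the two values shown. Compound 1, `COc1ccccc1C1C(C#N)=C(N)N(c2ccc(S(N)(=O)=O)cc2)C2=C1C(=O)CCC2`, gives in this assay only a limit of > 100 ug/mL. Among the measured compounds shown here, the one measured step, an at least 4.0-fold lower number from compound 1 to compound 2 (0.60 log units; beyond the scatter), therefore rests on that limit, (the limit of > 100 ug/mL in this assay, at which 1 of the 2 values shown sits), and its true size is known only from its lower bound. Compound 3, `N#CC1=C(N)N(c2ccc(S(N)(=O)=O)cc2)C2=C(C(=O)CCC2)C1c1c(O)ccc2ccccc12`, is not yet measured; its structure differs from compound 2 in one place: 2-hydroxynaphthalen-1-yl in place of 2,4-dichlorophenyl on a saturated ring carbon. For the measured compounds named here, the only step that bears on this change is the step from compound 1 to compound 2, which also replaces the group on the saturated ring carbon and was at least modest in size. An exchange of the aryl group at this position has thus moved the number beyond the scatter once, so a shift in either direction seems possible for compound 3, and a return toward weaker inhibition cannot be excluded. Compound 3 is therefore expected to give 40 ug/mL in this assay, with a range from 10 ug/mL to 150 ug/mL, a step of a 1.6-fold higher number from compound 2 to compound 3 (0.20 log units; within the scatter).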

Compound 3, half-maximal inhibitory concentration: > 100 ug/mL
Compound 3 ended at the assay's limit (the forecaster's own chance of this, stated with the estimate: 30%); middle value at least 2.5-fold (0.39 log units) away from the limit.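

In this assay, the exchange at this saturated ring carbon now proves able to move the number in the opposite direction: an at least 4.0-fold higher number from compound 2 to compound 3 (0.60 log units; beyond the scatter). The activity that could be read for compound 2 therefore does not carry over to every aryl group at this position, and it does not carry over to the 2-hydroxynaphthalen-1-yl group, despite its second six-membered aromatic ring of carbon only and its hydrogen-bond donor. Compound 1 and compound 3, whose groups at this carbon both carry oxygen, now stand together at the same end of the assay, so the step between them cannot be read, and only one of the three compounds has a true number: the limit of > 100 ug/mL in this assay, at which 2 of the 3 values shown sit.

From the compounds shown here alone, how far compound 1 and compound 3 lie past that limit stays open, and with it any order between the 2-methoxyphenyl and 2-hydroxynaphthalen-1-yl groups. The compounds shown also do not tell whether both chlorine atoms of compound 2 are needed, a question that a 4-chlorophenyl, a 2-chlorophenyl or an unsubstituted phenyl group at this carbon would bear on.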